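The source may report more compounds than this note shows. Statements on the series, on what has been measured and on what is new or still open speak of the compounds shown alone.

Three ureas have been measured in an assay on microsomes from intestine for inhibition of acyl-CoA:cholesterol acyltransferase (Oryctolagus cuniculus); on this read-out higher numbers stand for weaker inhibition and lower numbers for stronger inhibition. Compound 1 `Cc1cc(C)c(NC(=O)N(Cc2cc(-c3ccccc3)on2)C2CCCCCC2)c(C)c1` gives 61 nM. Compound 2 `O=C(Nc1c(F)cc(F)cc1F)N(Cc1ccc(-c2ccccn2)cc1)C1CCCCCC1` gives 25 nM. Compound 3 `Cc1cc(C)c(NC(=O)N(Cc2ccc(-c3ccccn3)cc2)C2CCCCCC2)c(C)c1` gives 33 nM. The step of a 1.3-fold higher number from compound 2 to compound 3 (0.12 log units; within the scatter) exchanges only the aryl group on the urea nitrogen, so it leaves the biaryl side untouched. On the bare numbers compound 3 is neither the lowest nor the highest of the three, yet its gaps to compound 2 and to compound 1 both lie within the usual scatter, so no ranking can be read from them.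

Compound 4 `Cc1cc(C)c(NC(=O)N(Cc2ccc(-n3ccnc3)cc2)C2CCCCCC2)c(C)c1` differs from compound 3 in one place: 1H-imidazol-1-yl in place of pyridin-2-yl on an aromatic carbon, keeping the para relationship to the large group on the carbon-only six-membered ring. Among the compounds with values here, no measured step touches this position; the only step on record, from compound 2 to compound 3, concerns the other end of the molecule, and compound 1 differs from compound 3 in more than one place, so its value can only be set beside that of compound 3 without any conclusion. Given this, the change is expected to produce no step beyond the scatter, a 1.4-fold higher number from compound 3 to compound 4 (0.13 log units; within the scatter), and compound 4 is estimated at 45 nM in this assay, within a range from 15 nM to 140 nM.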

Compound 4, half-maximal inhibitory concentration: 47 nM
For compound 4 the middle estimate is 1.0-fold (0.02 log units) below the measured one; the measured number falls inside the stated range.
By their numbers in this assay, from the lowest: compounds 2, 3, 4 and 1 (each within the scatter of the next, the first and the last beyond it).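

In this assay, within the data shown here, this is the first measured change at this place on the molecule, and the exchange of pyridin-2-yl for 1H-imidazol-1-yl gives a 1.4-fold higher number from compound 3 to compound 4 (0.15 log units; within the scatter). The two groups differ in ring size, in the number of hetero atoms and in the number of hydrogen-bond acceptors, yet compound 3 and compound 4 cannot be told apart here, so for this one pair, those differences at this place on the carbon-only six-membered ring leave no mark beyond the usual spread of repeated measurements. No supporting measurement is available to explain why the two compounds read alike.

As far as these compounds go, what remains open is whether this tolerance extends beyond aromatic rings, for instance to a morpholine ring, a simple amine or a carboxylic acid in the same place, any of which would test the position far harder than one aromatic ring exchanged for another. It is also open whether 1H-imidazol-1-yl would read the same with 2,4,6-trifluorophenyl in place of 2,4,6-trimethylphenyl on the urea nitrogen, a pairing that none of the compounds shown carries.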